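This account rests on a few compounds, and the source may have more. Where it says the series, first, only, none or still open, it means among the compounds named here.

Measured compounds:
compound 1 `Cc1ccc(Nc2cc(NC(=O)Nc3c(Cl)cccc3Cl)ncn2)cc1F` gives 40.7% in a functional assay on NCI-H226 cells (Homo sapiens) for inhibition, read by MTT assay, with a stated time of 48 h, tested at 10 uM; on this read-out lower numbers stand for less inhibition and higher numbers for more inhibition at the one concentration tested (going by the name of the read-out);
compound 2 `Cc1cc(F)cc(Nc2cc(NC(=O)Nc3c(Cl)cccc3Cl)ncn2)c1` gives 78.1%;
compound 3 `COc1cc(NC(=O)Nc2cc(Nc3cccc(C(C)(C)C)c3)ncn2)cc(OC)c1` gives 40%.

Compound 3 stands lowest of the three numbers in this assay, though its gap to compound 1 lies within the scatter; only compound 2 stands clearly above it. The unmeasured compound 4 `COc1cc(NC(=O)Nc2cc(Nc3cc(F)ccc3OC)ncn2)cc(OC)c1` differs from compound 3 in one place: 5-fluoro-2-methoxyphenyl in place of 3-(tert-butyl)phenyl on a nitrogen on an aromatic ring.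

Among the measured compounds shown here, only one measured step bears on this change, and only by kind: a number 37.4 percentage points higher from compound 1 to compound 2 (beyond the scatter). It shows that exchanging the aryl group on the nitrogen of the shared core can move the read-out strongly, but that step involves different groups from the one here, so its direction cannot be carried over. The change from compound 3 to compound 4 is therefore expected to bring a step of uncertain direction, a number 5 percentage points higher from compound 3 to compound 4 (within the scatter), with a wide range. Compound 4 is estimated at 45%, between 20% and 75%.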

Compound 4, a percentage reported as inhibition, at one concentration (the size of the read-out at that concentration, not a potency): 37.7%
Beside the measured number, compound 4's estimate is 7.3 percentage points above it, and the stated range covers the measured number.
By their numbers in this assay, from the lowest: compounds 4, 3 and 1 (each within the scatter of the next); then compound 2.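

The exchange gives a number 2.3 percentage points lower from compound 3 to compound 4 (within the scatter) in this assay, so at this place, on a nitrogen on an aromatic ring, 5-fluoro-2-methoxyphenyl and 3-(tert-butyl)phenyl cannot be told apart, even though they differ in their atoms and the entering group carries a hydrogen-bond acceptor. The earlier step, a number 37.4 percentage points higher from compound 1 to compound 2 (beyond the scatter), showed that a change of aryl group at this place can matter greatly; this result shows that a change of aryl group need not do so, at least with the rest of compound 3 in place. Nothing available bears on why the read-out responds to one exchange and not the other.

Going by these compounds, it remains open whether the 3-fluoro-5-methylphenyl group of compound 2 would raise the read-out with the rest of compound 3 in place. The shown compounds also leave open how an aryl group bearing an amine or a carboxylic acid would read at this place.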